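The compounds below may be only part of what the source reports. "The series", "measured", "known", "first", "only" and "open" are said of these compounds alone.

Within the data shown here, in a functional assay on HeLa cells (Homo sapiens) for cytotoxicity, read by neutral red uptake, with a stated time of 3 days (on this read-out higher numbers stand for weaker inhibition and lower numbers for stronger inhibition), compound 2 `Nc1ccc(-c2cc(=O)c3c(N)c(F)c(N)c(F)c3o2)cc1F` gives 19000 nM, the only actual number so far. Compound 1 `Cc1c(F)c(N)c2c(=O)cc(-c3ccc(N)c(F)c3)oc2c1F` is reported only as a limit of the assay, > 100000 nM. Among the measured compounds shown here, the single measured step, with amino in place of methyl on an aromatic carbon, is an at least 5.2-fold lower number from compound 1 to compound 2 (0.72 log units; beyond the scatter). Compound 3 `CCOC(=O)c1c(F)c(N)c2c(=O)cc(-c3ccc(N)c(F)c3)oc2c1F` changes that same carbon again: ethoxycarbonyl in place of amino on an aromatic carbon. For the measured compounds named here, compound 3 therefore lacks the amino that marks compound 2, and the step of an at least 5.2-fold lower number from compound 1 to compound 2 (0.72 log units; beyond the scatter) is the only guide to what losing it may do. A move towards higher numbers in this assay is therefore expected, of modest size, although ethoxycarbonyl itself has not been measured and compound 3 may also return only a limit. The expected step is a 2.4-fold higher number from compound 2 to compound 3 (0.37 log units; beyond the scatter). For compound 3 the estimated value is 45000 nM, with an expected range from 12000 nM to 120000 nM.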

Compound 3, half-maximal inhibitory concentration: > 100000 nM
Compound 3 was reported as a limit (the forecaster's own chance of this, stated with the estimate: 35%); at least 2.2-fold (0.34 log units) between middle value and limit.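

In this assay, ethoxycarbonyl in place of amino on this aromatic carbon gives an at least 5.2-fold higher number from compound 2 to compound 3 (0.72 log units; beyond the scatter). The amino of compound 2 has now been set against two different groups on the same carbon, methyl in compound 1 and ethoxycarbonyl in compound 3, and among the three compounds only the amino gives a number rather than a limit. The step between methyl and ethoxycarbonyl cannot be read, since compound 1 and compound 3 both rest on a limit: the limit of > 100000 nM in this assay, at which 2 of the 3 values shown sit.

From the compounds shown here alone, it remains open whether a measurable number is tied to the amino alone, or whether another group on this carbon, such as a hydroxyl, a methylamino or a carboxylic acid, would also give one. Going by these compounds, how far compound 1 and compound 3 lie beyond the limit also stays unknown.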